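Benzyloxy aryl variation on the shared core

This account rests on a few compounds, and the source may have more. Where it says the series, first, only, none or still open, it means among the compounds named here.

compound 1 `Cc1ccccc1COc1ccc(-c2cc(CN3CCN(Cc4ccc(C(F)(F)F)cc4)CC3)no2)cc1`: 6800 nM
compound 2 `Fc1cccc(COc2ccc(-c3cc(CN4CCN(Cc5ccc(C(F)(F)F)cc5)CC4)no3)cc2)c1`: 2900 nM

In a functional assay on Mahlavu cells (Homo sapiens) for antiproliferative activity, read by sulforhodamine B assay, with a stated time of 72 h (a higher number here means a weaker inhibitor, a lower number a stronger inhibitor), compound 1 gives 6800 nM, the highest of the two numbers; nearest is compound 2, which gives 2900 nM, the step being a 2.3-fold lower number from compound 1 to compound 2 (0.37 log units; beyond the scatter). Compound 3 `COc1cc(COc2ccc(-c3cc(CN4CCN(Cc5ccc(C(F)(F)F)cc5)CC4)no3)cc2)cc(OC)c1OC` is not yet measured and differs from compound 1 by 3,4,5-trimethoxyphenyl in place of 2-methylphenyl on a saturated chain carbon bound to an oxygen on an aromatic ring. Among the compounds with values here, the single measured step also swaps the aryl group on a saturated chain carbon bound to an oxygen on an aromatic ring and was modest, so for compound 3 a modest downward step, or none beyond the scatter, is expected. Compound 3 is estimated at 4000 nM (range 1500 nM to 12000 nM), an expected step of a 1.7-fold lower number from compound 1 to compound 3 (0.23 log units; within the scatter).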

Compound 3, half-maximal inhibitory concentration: 5800 nM
Beside the measured number, compound 3's estimate is 1.5-fold (0.16 log units) below it; the range from low to high includes it.
By their numbers in this assay, from the lowest: compounds 2, 3 and 1 (each within the scatter of the next, the first and the last beyond it).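

Replacing 2-methylphenyl with the larger 3,4,5-trimethoxyphenyl, which carries hydrogen-bond acceptors, on a saturated chain carbon bound to an oxygen on an aromatic ring leaves this assay essentially unchanged, with a 1.2-fold lower number from compound 1 to compound 3 (0.07 log units; within the scatter). Replacing 3-fluorophenyl with the same group gives a 2.0-fold higher number from compound 2 to compound 3 (0.30 log units; within the scatter), so compound 3 cannot be ordered against either compound, and this position accepts the added acceptors without a step beyond the scatter. No available evidence bears on this result. The compounds shown leave open how a cyclohexyl group in place of the aryl ring, or an amine or carboxylic acid on it, would read.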